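Two Measured Esters and an Expected Third

This account rests on a few compounds, and the source may have more. Where it says the series, first, only, none or still open, it means among the compounds named here.

Compound 1 `CSCC[C@H](NC(=O)CN(c1nc(Cl)nc2[nH]cnc12)C1CC1)C(=O)OCc1ccccc1`: 30.8% in a functional assay on the whole organism (Tail, strain ICR) with Mus musculus as the target, in the tail flick test, with a stated time of 60 min, at a dose of 25 umol/kg by the oral route; a lower number here means a weaker effect, a higher number a stronger effect of the compound at the dose given
Compound 2 `NC(=O)CC[C@H](NC(=O)CN(c1ncnc2c1ncn2C1CCCCO1)C1CC1)C(=O)OCc1ccccc1`: 39.4% in this assay

Among the measured compounds shown here, only two compounds have numbers in this assay. Compound 1 gives 30.8%, the smaller of the two, while compound 2 gives 39.4%; the distance between them lies within the scatter of repeated measurements, so the two cannot be told apart on these numbers. For the measured compounds named here, no pair of measured compounds differs in a single place, so there is no measured step from which a trend could be read.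

Compound 3 `O=C(CN(c1nc(Cl)nc2[nH]cnc12)C1CC1)N[C@@H](CCC(=O)OCc1ccccc1)C(=O)OCc1ccccc1` has not been measured in this assay. It differs from compound 1 in one place: benzyloxycarbonyl in place of methylsulfanyl on a saturated chain carbon, three bonds along the chain from an amide-type nitrogen and a carbonyl carbon. Going by the values given here, with no measured step of a comparable kind to rest on, the expectation for the step from compound 1 to compound 3 is one of about a number 2.2 percentage points higher from compound 1 to compound 3 (within the scatter), that is, nothing clearly beyond the scatter in either direction. Compound 3 is therefore expected to give about 33% in this assay, within a range from 15% to 55%.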

Compound 3, a percentage reported as activity, at one dose (the size of the read-out at that dose, not a potency): 53.7%
Compound 3: the middle estimate sits 20.7 percentage points below what was measured; the measured number falls inside the stated range.
By their numbers in this assay, from the lowest: compounds 1 and 2 (each within the scatter of the next); then compound 3.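

Placing benzyloxycarbonyl where methylsulfanyl stood, on a saturated chain carbon, three bonds along the chain from an amide-type nitrogen and a carbonyl carbon, gives the first single-place step in this assay: a number 22.9 percentage points higher from compound 1 to compound 3 (beyond the scatter). This position therefore accepts a group with one six-membered aromatic ring of carbon only and a double bond outside aromatic rings, and the read-out at this dose rises rather than falls, something compounds 1 and 2 alone could not show, as they differ in more than one place. Nothing at hand bears on why the read-out moves with this change.

Among the compounds shown here, the change removes sulfur and adds a carbonyl, an ester oxygen and an aromatic ring in one exchange, so the single step cannot assign the rise to any one of these parts. Going by these compounds, whether the ring or the ester linkage carries the rise remains open, and a carboxylic acid or a plain phenyl group at the same place would be needed to separate them.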